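This account rests on a few compounds, and the source may have more. Where it says the series, first, only, none or still open, it means among the compounds named here.

Measured values (a functional assay on HCT-116 cells (Homo sapiens) for inhibition, read by MTT assay, with a stated time of 48 h; on this read-out higher numbers stand for weaker inhibition and lower numbers for stronger inhibition):
- Compound 1 `COc1ccc(CN(C(=O)C(C)Br)c2cc(OC)c(OC)c(OC)c2)cc1O` gives 140 nM
- Compound 2 `C/C=C/C=C/C(=O)N(Cc1ccc(OC)c(O)c1)c1cc(OC)c(OC)c(OC)c1` gives 180 nM
- Compound 3 `CCC/C=C/C(=O)N(Cc1ccc(OC)c(O)c1)c1cc(OC)c(OC)c(OC)c1` gives 95 nM

Compound 3 stands level with the other two, since both of its steps lie within the scatter (a 1.5-fold lower number from compound 1 to compound 3 (0.17 log units; within the scatter)) and (a 1.9-fold lower number from compound 2 to compound 3 (0.28 log units; within the scatter)). The unmeasured compound 4 `COc1ccc(CN(C(=O)CCCl)c2cc(OC)c(OC)c(OC)c2)cc1O` keeps the shared core and alters only the group on the carbonyl carbon, with 2-chloroethyl in place of pent-1-en-1-yl (2-chloroethyl in place of pent-1-en-1-yl on a carbonyl carbon).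

Among the compounds with values here, the steps that bear on this change are those that swap the group at the same place. Replacing 1-bromoethyl with pent-1-en-1-yl gave the first step above, and replacing it with penta-1,3-dien-1-yl gave a similarly small one (a 1.3-fold higher number from compound 1 to compound 2 (0.11 log units; within the scatter)). Neither left the scatter, so these three compounds offer no sign that this position moves the number much. None of them carries 2-chloroethyl, however, so the data cannot test that group directly.

The expectation leans towards compound 1 (140 nM), whose 1-bromoethyl is also a halogen-carrying ethyl group. A slightly higher number is therefore expected, with an estimated step that stays within the scatter (a 1.6-fold higher number from compound 3 to compound 4 (0.20 log units; within the scatter)). In this assay the expected value for compound 4 is 150 nM within a range of 60 nM to 380 nM (estimated).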

Compound 4, half-maximal inhibitory concentration: 150 nM
Estimate against measurement, compound 4: no gap at the digits printed, within the range that was stated.
By their numbers in this assay, from the lowest: compounds 3, 1, 4 and 2 (each within the scatter of the next).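

In this assay, the group on the carbonyl carbon can lose its double bond, go from the 5 heavy atoms of pent-1-en-1-yl to the 3 of 2-chloroethyl, and gain a chlorine, and the step still stays within the scatter (a 1.6-fold higher number from compound 3 to compound 4 (0.20 log units; within the scatter)). The same holds against the other two groups, both for the penta-1,3-dien-1-yl of compound 2 (a 1.2-fold lower number from compound 2 to compound 4 (0.08 log units; within the scatter)) and for the halogen-carrying 1-bromoethyl of compound 1 (a 1.1-fold higher number from compound 1 to compound 4 (0.03 log units; within the scatter)), so all four compounds stand level and none goes against this flat picture. Nothing available explains why these different chains stand level, so the flat picture is an observation without a known cause.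

Going by these compounds, whether the flat picture would survive a phenyl ring, an amine, a carboxylic acid or a much longer chain on the carbonyl carbon remains open. On these data alone, it is also open whether the chlorine of compound 4 matters at all, a question that a plain ethyl group at the same place would help to settle.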